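A Fluoro Step on the Benzyl Ring of a Weak Binder

This account rests on a few compounds, and the source may have more. Where it says the series, first, only, none or still open, it means among the compounds named here.

Compound 3 `CNc1nc(-c2ccccc2)nc2c1nnn2Cc1ccccc1` gives 353000000 nM in an assay on isolated protein for binding affinity to adenosine receptor A1 (Bos taurus) (a lower number here means a stronger inhibitor, a higher number a weaker inhibitor), the highest of the three numbers measured; compound 2 `OCCNc1nc(-c2ccccc2)nc2c1nnn2Cc1ccccc1F` gives 54000000 nM and compound 1 `COc1ccc(C(=O)Nc2nc(-c3ccccc3)nc3c2nnn3Cc2ccccc2F)cc1` gives 21900000 nM. Compound 4 `CNc1nc(-c2ccccc2)nc2c1nnn2Cc1ccccc1F` differs from compound 3 by fluoro in place of hydrogen on an aromatic carbon, benzyl becoming 2-fluorobenzyl. Among the measured compounds shown here, no measured step covers this change: the only step, a 2.5-fold higher number from compound 1 to compound 2 (0.39 log units; beyond the scatter), alters a different part of the molecule. Compounds 1 and 2 both carry the 2-fluorobenzyl and sit well below compound 3, yet they differ from it elsewhere too, so the bearing is indirect. A modest lowering of the number is therefore expected, a 2.4-fold lower number from compound 3 to compound 4 (0.37 log units; beyond the scatter). Compound 4 is estimated at 150000000 nM, within 40000000 nM to 500000000 nM.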

Compound 4, inhibition constant: 25000000 nM
Compound 4: the middle estimate sits 6.0-fold (0.78 log units) above what was measured; the measured number lies below the stated range.
By their numbers in this assay, from the lowest: compounds 1 and 4 (each within the scatter of the next); then compound 2; then compound 3.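

In this assay the fluoro in place of hydrogen on the benzyl ring brings a 14-fold lower number from compound 3 to compound 4 (1.15 log units; beyond the scatter), the largest step among these compounds. With 2-fluorobenzyl held fixed, changes on the nitrogen count for less: a 2.2-fold lower number from compound 2 to compound 4 (0.33 log units; beyond the scatter) is modest, and a 1.1-fold higher number from compound 1 to compound 4 (0.06 log units; within the scatter) lies within the scatter. Nothing shown here explains the size of the fluoro step. Going by these compounds, whether chloro or methoxy at the same place would give a similar step remains open, as does whether the groups on the nitrogen would differ as little on an unsubstituted benzyl.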